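Methyl for Amino on the Amide Nitrogen

The source may report more compounds than this note shows. Statements on the series, on what has been measured and on what is new or still open speak of the compounds shown alone.

Compound 1: `Cc1cc(CCC#N)cc(C)c1Oc1cc(Nc2ccc(C#N)cc2)c(N)cc1S(N)(=O)=O`, 11100 nM
Compound 2: `Cc1cc(CCC#N)cc(C)c1Oc1cc(Nc2ccc(C#N)cc2)c(N)cc1C(=O)NN`, > 22700 nM

Both compounds were tested in an ADME assay on TZM cells (Homo sapiens) for cytotoxicity, read by XTT assay, with a stated time of 4 days; on this read-out higher numbers stand for lower toxicity in this test and lower numbers for higher toxicity in this test. Compound 1 gives 11100 nM. For compound 2 the result is only a limit of the test, > 22700 nM. Going from compound 1 to compound 2 put aminocarbamoyl in place of sulfamoyl on an aromatic carbon, and the number rose: an at least 2.0-fold higher number from compound 1 to compound 2 (0.31 log units; beyond the scatter). Because compound 2 sits at the limit of > 22700 nM in this assay, at which 1 of the 2 values shown sits, the size of that step is known only as a lower bound.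

Compound 3, `CNC(=O)c1cc(N)c(Nc2ccc(C#N)cc2)cc1Oc1c(C)cc(CCC#N)cc1C`, has not yet been measured. It differs from compound 2 by methyl in place of amino on an amide-type nitrogen. Going by the values given here, the one measured step concerns the group on the aromatic carbon, not the amide nitrogen, so no measured step bears directly on this change, and no shift beyond the scatter is expected in this assay. Compound 3 is therefore estimated at 25000 nM, within 11000 nM to 60000 nM. This estimate corresponds to an expected step that the limit leaves unreadable from compound 2 to compound 3.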

Compound 3, half-maximal cytotoxic concentration: > 9100 nM
Compound 3 ended at the assay's limit (the forecaster's own chance of this, stated with the estimate: 60%); the middle value lies beyond the limit too.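

In this assay compound 3 gives > 9100 nM as a limit of the test, not a number. Compound 2 also stands at a limit, so the steps from compound 1 and from compound 2 to compound 3 cannot be read. On these data alone, whether methyl or amino on the amide-type nitrogen gives the higher number in this assay stays open.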